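Shrinking the aryl group on compound 1's core to methyl

A few compounds are considered here, and "the series" means these few. Any claim that something is new, unique, unknown or untested is made for them only; others in the source may bear on it.

Among the compounds with values here, compound 1 `C/C(=N\Nc1nc(-c2ccc(C)cc2)cs1)c1cc2ccccc2o1` gives 14100 nM in a functional assay on HepG2 cells (Homo sapiens) for antiproliferative activity; on this read-out higher numbers stand for weaker inhibition and lower numbers for stronger inhibition; it stands at the top of the two numbers in hand, and the only measured step, a 1.4-fold lower number from compound 1 to compound 2 (0.14 log units; within the scatter), is within the scatter. Compound 2 `C/C(=N\Nc1nc(-c2ccccc2)cs1)c1cc2ccccc2o1` gives 10300 nM in this assay. Compound 3 `C/C(=N\Nc1nc(C)cs1)c1cc2ccccc2o1` differs from compound 1 by methyl in place of 4-methylphenyl on an aromatic carbon. That single measured step concerned only the loss of a methyl from the aryl group; removing the whole ring is a far larger change, and nothing measured covers it. Compound 3 is therefore expected to move by a 1.8-fold higher number from compound 1 to compound 3 (0.25 log units; within the scatter), toward a weaker reading. Compound 3 is estimated at 25000 nM, between 8000 nM and 80000 nM.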

Compound 3, half-maximal inhibitory concentration: 4000 nM
Beside the measured number, compound 3's estimate is 6.3-fold (0.80 log units) above it; the measured number lies below the stated range.
By their numbers in this assay, from the lowest: compound 3; then compounds 2 and 1 (each within the scatter of the next).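

At this aromatic carbon next to the ring nitrogen, the aryl group can be given up without loss in this assay: methyl in place of 4-methylphenyl brings a 3.5-fold lower number from compound 1 to compound 3 (0.55 log units; beyond the scatter), and methyl in place of phenyl brings a 2.6-fold lower number from compound 2 to compound 3 (0.41 log units; beyond the scatter). The methyl group thus reads stronger than either aryl group, whereas removing the methyl from the aryl ring had produced a step only within the scatter. Nothing available explains this result. On these data alone, whether hydrogen, an amine, a carboxylic acid or a longer chain such as propyl at this carbon would give a lower number remains open.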